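This account rests on a few compounds, and the source may have more. Where it says the series, first, only, none or still open, it means among the compounds named here.

Compound 1 `Cc1ccc(S(=O)(=O)OCCCc2cn(-c3ccc(C(F)(F)F)cc3)nn2)cc1`: 42700 nM
Compound 2 `COC(=O)c1ccc(-n2cc(CCCOS(=O)(=O)c3ccc(C)cc3)nn2)cc1`: > 100000 nM

In a functional assay on HepG2 cells (Homo sapiens) for cytotoxicity, read by MTT assay, with a stated time of 72 h (a lower number here means a stronger inhibitor, a higher number a weaker inhibitor), compound 2 gives > 100000 nM, which is a limit and not a number. Compound 2 therefore sits at the limit of > 100000 nM in this assay, at which 1 of the 2 values shown sits.

Compound 3 `COc1ccc(-n2cc(CCCOS(=O)(=O)c3ccc(C)cc3)nn2)cc1` keeps the rest of compound 2 and changes one group: methoxy in place of methoxycarbonyl on an aromatic carbon. In words, this is methoxy in place of methoxycarbonyl on an aromatic carbon, para to a large group.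

Going by the values given here, only one measured step bears on this change, and it involves the same group of compound 2. That step is an at least 2.3-fold higher number from compound 1 to compound 2 (0.36 log units; beyond the scatter), which lies beyond the scatter. It shows that the group at this place can shift the reading, but it contains no methoxy, so it gives only a rough guide. A return to a measurable number is expected because compound 1 gives 42700 nM with a different group there. Compound 3 may still stay at the limit of this assay.

A modest move towards a lower number is expected, estimated as an at least 1.5-fold lower number from compound 2 to compound 3 (0.18 log units; that floor lies within the scatter). The estimate for compound 3 is 65000 nM, with an expected range from 30000 nM to 140000 nM.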

Compound 3, half-maximal inhibitory concentration: > 100000 nM
Compound 3 was reported as a limit; the forecaster's own chance of this, stated with the estimate: 40%; middle value at least 1.5-fold (0.18 log units) away from the limit.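

Methoxy in place of trifluoromethyl on this aromatic carbon, para to a large group, gives an at least 2.3-fold higher number from compound 1 to compound 3 (0.36 log units; beyond the scatter) in this assay, so the higher number seen with methoxycarbonyl also appears with a group of fewer heavy atoms and only one hydrogen-bond acceptor. Among the three groups shown at this place, only trifluoromethyl, in compound 1, gives a measurable number, 42700 nM. Methoxycarbonyl and methoxy both leave the reading at the limit of this assay. The step from compound 2 to compound 3 cannot be read, because the values of both compounds are limits and not numbers: the limit of > 100000 nM in this assay, at which 2 of the 3 values shown sit.

Going by these compounds, how far compound 2 and compound 3 lie past that limit remains unknown, so the two groups cannot be put in order, and neither compound shows how weak it really is in this assay. On these data alone, whether another group at this place, such as an amine or a carboxylic acid, would give a measurable number, and whether any group would give a lower number than trifluoromethyl, also stays open.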